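This account rests on a few compounds, and the source may have more. Where it says the series, first, only, none or still open, it means among the compounds named here.

Measured in an ADME assay on BJ cells (Homo sapiens) for cytotoxicity, read by CellTiter-Glo, with a stated time of 72 h; on this read-out higher numbers stand for an effect only at larger amounts of compound and lower numbers for an effect already at smaller amounts:

Compound 1 `C=C1/C=C/C(C)(C)CC2=C(C)C(=O)[C@]3(C[C@@H](C)C=C3/C=C\1C)O2`: 26000 nM
Compound 2 `CC1=C2CC(C)(C)/C=C/C/C(C)=C\C3=C[C@H](C)C[C@]3(O2)C1=O`: 26000 nM
Compound 3 `COc1ccc(/C2=C\C(=O)/C(C)=C\C3=C[C@H](C)C[C@@]34OC(=C(C)C4=O)CC2(C)C)cc1`: 26000 nM

Compound 3 stands level with the other two, and in this assay compound 3 gives 26000 nM. Its nearest relative in this account is compound 4 `CC1=C2CC(C)(C)/C(c3ccccc3)=C/C(=O)/C(C)=C\C3=C[C@H](C)C[C@]3(O2)C1=O`, which has not yet been measured. Compound 4 carries phenyl where compound 3 carries 4-methoxyphenyl: hydrogen in place of methoxy on an aromatic carbon. Put simply, this is hydrogen in place of methoxy on an aromatic carbon, para to a large group.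

Among the compounds with values here, no measured pair differs in one place, so no direct precedent exists for this change. Compound 2 has no 4-methoxyphenyl group at all, yet compound 2 gives 26000 nM. On that basis, no step beyond the scatter is expected in this assay, in either direction. The estimated change is no change at the digits printed from compound 3 to compound 4 (within the scatter). The expected value for compound 4 is 26000 nM, with an estimated range of 14000 nM to 40000 nM.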

Compound 4, half-maximal effective concentration: 26000 nM
The estimate for compound 4 equals the measured number at the digits printed; the measured number falls inside the stated range.
By their numbers in this assay, from the lowest: compounds 1, 2, 3 and 4 (each within the scatter of the next).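

In this assay, within the data shown here, the exchange of 4-methoxyphenyl for phenyl gives the first step that can be read directly at this position: no change at the digits printed from compound 3 to compound 4 (within the scatter). Among these compounds, until now, no two measured compounds differed in one place, so nothing showed what this site does on its own. The result shows that, in this read-out, hydrogen in place of methoxy on an aromatic carbon, para to a large group, leaves the value within the scatter. No measurement is at hand that would explain this result.

As far as these compounds go, what remains open is whether any other group at this place would behave in the same way, for example an amine or a carboxylic acid in place of the methoxy. Also open, from the compounds shown here alone, is whether the same exchange would read alike on a different core.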